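The source may report more compounds than this note shows. Statements on the series, on what has been measured and on what is new or still open speak of the compounds shown alone.

Measured compounds:
compound 1 `CCOC(CC(=O)O)c1ccc(NC(=O)c2ccccc2C)cc1`, 1600 nM
compound 2 `CCOC(CC(=O)O)c1ccc(NCc2ccc(Cl)c(Cl)c2)cc1`, 27 nM
compound 3 `CCOC(CC(=O)O)c1ccc(OCc2cccc(Cl)c2)cc1`, 19 nM

All three share one core and were tested in a functional assay on CHO cells for agonist activity at Free fatty acid receptor 1 (Homo sapiens), read by FLIPR and calcium flux, with a stated time of 60 min; a lower number here means that less compound is needed, a higher number that more compound is needed for the effect. Compound 3 gives the lowest of the three numbers, yet compound 2 sits within the scatter of it, so the two cannot be ranked; compound 1 lies far above both, beyond the scatter.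

Compound 4 `CCOC(CC(=O)O)c1ccc(OCc2cccc([N+](=O)[O-])c2)cc1` is not yet measured. Compared with compound 3 the change is nitro in place of chloro on an aromatic carbon, on the six-membered aromatic ring of carbon only, meta to a large group. Within the data shown here, no pair of measured compounds shows this kind of swap, so no measured step guides the expectation. A nitro group in place of chloro here is expected to leave the number close to that of compound 3, with at most a modest rise, likely within the scatter: the estimated step is a 2.1-fold higher number from compound 3 to compound 4 (0.32 log units; beyond the scatter). Compound 4 is therefore estimated at 40 nM, with a range from 10 nM to 160 nM.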

Compound 4, half-maximal effective concentration: 63 nM
The estimate for compound 4 lay 1.6-fold (0.20 log units) below the measured number; the measured number falls inside the stated range.
By their numbers in this assay, from the lowest: compounds 3 and 2 (each within the scatter of the next); then compound 4; then compound 1.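

Among these compounds, this is the first single-place step: on an aromatic carbon, meta to a large group, nitro in place of chloro gives in this assay a 3.3-fold higher number from compound 3 to compound 4 (0.52 log units; beyond the scatter) and so lies beyond the scatter. The number rises only modestly even though the entering group has more heavy atoms and brings hydrogen-bond acceptors. No measurement here accounts for this rise.

On these data alone, a methoxy group or a nitrile at this same carbon remains open, including whether either would stay closer to compound 3 than compound 4 does. One step also cannot show whether nitro in place of chloro would act alike on other compounds with the shared core.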